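The compounds below may be only part of what the source reports. "The series", "measured", "known", "first", "only" and "open" are said of these compounds alone.

Compound 1 `O=C1/C(=C/c2ccncc2)CN(S(=O)(=O)c2ccc(Br)cc2)C/C1=C\c1ccccc1F`: 11500 nM
Compound 2 `N#Cc1ccc(S(=O)(=O)N2C/C(=C\c3ccncc3)C(=O)/C(=C/c3ccccc3F)C2)cc1`: 8500 nM

In a functional assay on QGY-7703 cells (Homo sapiens) for cytotoxicity, read by MTT assay, with a stated time of 24 h (a lower number here means a stronger inhibitor, a higher number a weaker inhibitor), compound 1 gives 11500 nM, the higher of the two values shown, and its nearest neighbour is compound 2, which gives 8500 nM; the step of a 1.4-fold lower number from compound 1 to compound 2 (0.13 log units; within the scatter) is within the scatter. Compound 3 `O=C1/C(=C/c2ccncc2)CN(S(=O)(=O)c2ccc(Br)cc2)C/C1=C\c1ccccc1C(F)(F)F` differs from compound 1 by trifluoromethyl in place of fluoro on an aromatic carbon. No measured step concerns this change: the one step shown, cyano in place of bromo on an aromatic carbon, lies elsewhere in the structure. For compound 3 the step of a 1.0-fold lower number from compound 1 to compound 3 (0.02 log units; within the scatter) is therefore expected to stay within the scatter, with no direction favoured. Compound 3 is estimated at 11000 nM, in the range 4000 nM to 30000 nM.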

Compound 3, half-maximal inhibitory concentration: 7060 nM
Estimate against measurement, compound 3: 1.6-fold (0.19 log units) above, and the stated range covers the measured number.
By their numbers in this assay, from the lowest: compounds 3, 2 and 1 (each within the scatter of the next).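

In this assay, trifluoromethyl in place of fluoro, on an aromatic carbon ortho to a large group, gives a 1.6-fold lower number from compound 1 to compound 3 (0.21 log units; within the scatter), so this position, which the earlier step did not touch, accepts 4 heavy atoms in place of 1 without a change beyond the scatter. No measurement is available that would explain this result. Still open, going by these compounds, is whether an amine or a carboxylic acid at this position would shift the number beyond the scatter, and whether trifluoromethyl would behave alike in the nitrile-bearing compound 2.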